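The compounds below may be only part of what the source reports. "The series", "measured", "known", "first", "only" and "open" are said of these compounds alone.

In a functional assay on MCF7 cells (Homo sapiens) for antiproliferative activity, read by sulforhodamine B assay, with a stated time of 48 h (on this read-out lower numbers stand for stronger inhibition and higher numbers for weaker inhibition), three compounds sharing one core have been measured. Compound 1 `Cc1cccc(NS(=O)(=O)c2ccc(N3CCNC3=O)cc2)c1` gives 190 nM, compound 2 `O=C1NCCN1c1ccc(S(=O)(=O)Nc2cccc(Br)c2)cc1` gives 100 nM, and compound 3 `O=C1NCCN1c1ccc(S(=O)(=O)Nc2ccc(Cl)cc2)cc1` gives 170 nM. Compound 3 sits within this tight group rather than apart from it. The data show a 1.1-fold lower number from compound 1 to compound 3 (0.05 log units; within the scatter) and a 1.7-fold higher number from compound 2 to compound 3 (0.23 log units; within the scatter), while the remaining comparison is a 1.9-fold lower number from compound 1 to compound 2 (0.28 log units; within the scatter). None of these steps separates the compounds beyond the scatter.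

The next compound to be tested is compound 4 `Cc1ccccc1NS(=O)(=O)c1ccc(N2CCNC2=O)cc1`. It differs from compound 3 in one place: 2-methylphenyl in place of 4-chlorophenyl on a sulfonamide nitrogen. This puts 2-methylphenyl in place of 4-chlorophenyl on a sulfonamide nitrogen, with the rest of the structure unchanged.

The most relevant evidence is the exchange of the group at this same nitrogen, seen in a 1.1-fold lower number from compound 1 to compound 3 (0.05 log units; within the scatter) and a 1.7-fold higher number from compound 2 to compound 3 (0.23 log units; within the scatter). Both exchanges stayed small, so a similar swap is expected to produce no change beyond the scatter, and no direction can be favoured. Among the compounds with values here, the caution is that no measured compound carries the 2-methylphenyl group, so the data cannot show how this particular group behaves, and the range is kept wide.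

The expected result is a 1.2-fold higher number from compound 3 to compound 4 (0.07 log units; within the scatter). For compound 4, the estimated value in this assay is 200 nM, with an expected range from 75 nM to 550 nM.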

Compound 4, half-maximal inhibitory concentration: 280 nM
The estimate for compound 4 lay 1.4-fold (0.15 log units) below the measured number, and the stated range covers the measured number.
By their numbers in this assay, from the lowest: compounds 2, 3, 1 and 4 (each within the scatter of the next, the first and the last beyond it).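

Within the data shown here, with the 2-methylphenyl group on the sulfonamide nitrogen, this assay yields the first step at this position that goes beyond the scatter, a modest one: a 2.8-fold higher number from compound 2 to compound 4 (0.45 log units; beyond the scatter) for 2-methylphenyl in place of 3-bromophenyl. The other two exchanges stay within the scatter, with a 1.6-fold higher number from compound 3 to compound 4 (0.22 log units; within the scatter) and a 1.5-fold higher number from compound 1 to compound 4 (0.17 log units; within the scatter) for 2-methylphenyl in place of 4-chlorophenyl and 3-methylphenyl, so compound 4 stands apart from compound 2 alone and the four compounds still span only a narrow range. Nothing available accounts for this one larger step.

As far as these compounds go, the four compounds carry only a methyl, bromo or chloro group on the phenyl ring at this nitrogen, so it remains open whether a 2-bromophenyl group would give a number closer to that of compound 2 or of compound 4, which would show whether the bromo or the methyl group matters more here. From the compounds shown here alone, it is also open whether an amine or a carboxylic acid on that ring, or a longer alkyl chain in place of the ring, would move the number further than any of these exchanges did.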